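This account rests on a few compounds, and the source may have more. Where it says the series, first, only, none or still open, it means among the compounds named here.

Compound 1, `CN1CCC(n2cc(S(=O)(=O)c3ccc(F)cc3)c3cccnc32)C1`: 85%
Compound 2, `CN1CCC(n2cc(S(=O)(=O)c3ccc(Cl)cc3)c3cccnc32)C1`: 98%
Compound 3, `CCN1CCC(n2cc(S(=O)(=O)c3cccc(F)c3)c3cccnc32)C1`: 89%

Of the compounds shown here, three have been measured in a functional assay on HeLa cells for antagonist activity at 5-hydroxytryptamine receptor 6 (Homo sapiens), read by cAMP accumulation and immunoassay; on this read-out lower numbers stand for smaller maximal responses and higher numbers for larger maximal responses. Compound 1, `CN1CCC(n2cc(S(=O)(=O)c3ccc(F)cc3)c3cccnc32)C1`, gives 85%, and compound 2, `CN1CCC(n2cc(S(=O)(=O)c3ccc(Cl)cc3)c3cccnc32)C1`, gives 98%. The change between them, (chloro in place of fluoro on an aromatic carbon), produced a number 13 percentage points higher from compound 1 to compound 2 (beyond the scatter). Compound 3, `CCN1CCC(n2cc(S(=O)(=O)c3cccc(F)c3)c3cccnc32)C1`, gives 89%; its values against compound 1 and compound 2 both fall within the usual scatter, so no order among these three is drawn from them. How the core of compound 3 differs from the core of compound 1 is not broken down here.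

Compound 4, `CCN1CCC(n2cc(S(=O)(=O)c3cccc(Cl)c3)c3cccnc32)C1`, has not been measured in this assay. It differs from compound 3 by chloro in place of fluoro on an aromatic carbon, the same kind of change as that from compound 1 to compound 2, but the place is not identical: in the earlier pair the group sits para to a large group, here it sits meta to a large group. The step from compound 3 to compound 4 is expected to be a number 8 percentage points higher from compound 3 to compound 4 (within the scatter), of roughly the earlier size, because the same kind of change gave a number 13 percentage points higher from compound 1 to compound 2 (beyond the scatter). Compound 4 is therefore expected near 97%, between 87% and 105%.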

Compound 4, largest response reached (reported as percent of maximum), in percent of the reference or control that the assay uses: 93%
For compound 4 the middle estimate is 4 percentage points above the measured one; measured number inside the range.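

Read on the core of compound 3, the change from 3-fluorophenyl to 3-chlorophenyl gave a number 4 percentage points higher from compound 3 to compound 4 (within the scatter) in this assay, so on this core its effect on the maximal response cannot be told apart from repeat measurement. Set beside the earlier step on the core of compound 1, the new step gives no sign that the change behaves differently from one core to the other: the same change on two cores in this assay, a number 13 percentage points higher (beyond the scatter) from compound 1 to compound 2 and a number 4 percentage points higher (within the scatter) from compound 3 to compound 4, 9 percentage points apart, within the scatter of two such steps. Among these compounds, this does not show that the change carries over at a fixed size, however, as only two pairs are available, the group sits in a different place in each, and only the earlier step lies beyond the scatter.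

The compounds shown leave open what the same change would do at one and the same place on both cores. They also leave open how a bromo, methoxy or nitrile group in place of the chloro would read in this assay.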